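Chloro for Fluoro in a Level Pair

The source may report more compounds than this note shows. Statements on the series, on what has been measured and on what is new or still open speak of the compounds shown alone.

In a functional assay on NCI60 cells (Homo sapiens) for cytotoxicity (on this read-out higher numbers stand for weaker inhibition of growth and lower numbers for stronger inhibition of growth), compound 1 (`COc1cccc(-c2cc(=O)c3ccc(C)nc3[nH]2)c1`) gives 269 nM. Compound 2 (`Cc1cnc2[nH]c(-c3cccc(F)c3)cc(=O)c2c1`) gives 269 nM, so it stands level with compound 1 at the digits reported. The next compound to be tested is compound 3 (`Cc1cnc2[nH]c(-c3cccc(Cl)c3)cc(=O)c2c1`), which has chloro in place of fluoro on an aromatic carbon of compound 2, meta to a large group. The difference is chloro in place of fluoro on an aromatic carbon. Among the measured compounds shown here, no two measured compounds differ in one place only, so the data give no direct guide to the size of such a change in this assay. The expectation therefore starts from compound 2 at 269 nM, and no shift beyond the usual scatter is anticipated in either direction. The expected step, a 1.1-fold lower number from compound 2 to compound 3 (0.05 log units; within the scatter), is small. For compound 3 the estimated value is 240 nM, with an expected range of 100 nM to 580 nM.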

Compound 3, concentration for 50% growth inhibition: 269 nM
Estimate against measurement, compound 3: 1.1-fold (0.05 log units) below; measured number inside the range.
By their numbers in this assay, from the lowest: compounds 1, 2 and 3 (each within the scatter of the next).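

Among the compounds shown here, the step from fluoro to chloro gives the first direct reading at this position. In this assay, chloro in place of fluoro on an aromatic carbon, meta to a large group, gives no change at the digits printed from compound 2 to compound 3 (within the scatter). Compounds 1 and 2 differ in more than one place and could not show this, whereas this pair shows that the read-out does not separate these two groups at this position. No supporting measurement bears on this result.

On these data alone, whether an amine or a carboxylic acid on the same aromatic carbon would give a similar reading remains open. As far as these compounds go, it is also open whether a longer chain there would leave the value unmoved, or whether the same exchange would read alike on the core of compound 1.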